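Chain extension on the shared core: compound 3 to compound 4

The source may report more compounds than this note shows. Statements on the series, on what has been measured and on what is new or still open speak of the compounds shown alone.

Three compounds have numbers in a functional assay on HT-29 cells (Homo sapiens) for cytotoxicity, read by neutral red uptake, with a stated time of 72 h; a lower number here means a stronger inhibitor, a higher number a weaker inhibitor. Compound 1 `Clc1ccc(CNc2nc(NCc3ccc(Cl)cc3)c3ccccc3n2)cc1` gives 5890 nM. Compound 2 `CCNc1nc(SCC)nc2ncccc12` gives 26200 nM. Compound 3 `CCCCNc1nc(SCC)nc2ncccc12` gives 25300 nM and stands second highest of the three numbers; its nearest neighbour is compound 2, within the scatter, while compound 1 lies furthest, beyond the scatter. Compound 4 `CCCCCNc1nc(SCC)nc2ncccc12` carries the change (methyl in place of hydrogen on a saturated chain carbon, four bonds along the chain from a nitrogen on an aromatic ring). Going by the values given here, the one measured step that bears on it is the earlier extension of the same chain, a 1.0-fold lower number from compound 2 to compound 3 (0.02 log units; within the scatter), which left the number essentially unchanged. Since lengthening this chain by one carbon earlier moved nothing beyond the scatter, compound 4 is expected to show a step of a 1.1-fold lower number from compound 3 to compound 4 (0.02 log units; within the scatter), that is, none beyond the scatter, because compound 2 and compound 3 are so close at 25300 nM. Compound 4 is therefore estimated at 24000 nM, with a range from 12000 nM to 48000 nM.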

Compound 4, half-maximal inhibitory concentration: 5100 nM
Estimate against measurement, compound 4: 4.7-fold (0.67 log units) above; the measured number lies below the stated range.
By their numbers in this assay, from the lowest: compounds 4 and 1 (each within the scatter of the next); then compounds 3 and 2 (each within the scatter of the next).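

In this assay, the methyl on a saturated chain carbon, four bonds along the chain from a nitrogen on an aromatic ring, gives a 5.0-fold lower number from compound 3 to compound 4 (0.70 log units; beyond the scatter) whereas the earlier extension of the same chain gave only a 1.0-fold lower number from compound 2 to compound 3 (0.02 log units; within the scatter). Taken from the shorter chain, the whole extension amounts to a 5.1-fold lower number from compound 2 to compound 4 (0.71 log units; beyond the scatter) so among these three compounds the number moves beyond the scatter only once the outermost carbon is present. Nothing available here accounts for this step.

The compounds shown leave open whether a longer chain would lower the number further, hold it, or reverse the step. They also leave open whether the step needs a plain carbon at this position, or whether a terminal amine or carboxylic acid on the chain would give a similar number.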